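This account rests on a few compounds, and the source may have more. Where it says the series, first, only, none or still open, it means among the compounds named here.

Going by the values given here, compound 2, with the structure `COC(=O)C1=C(C)NC(=S)NC1c1ccoc1`, stands highest of the two numbers known so far: in an assay on membranes from CHO cells for displacement of a labelled ligand from adenosine receptor A1 (Homo sapiens), read by scintillation counting, with a stated time of 60 min, tested at 1 uM (a higher number here means more inhibition at the concentration tested (going by the name of the read-out), a lower number less inhibition), compound 2 gives 25%. Its nearest neighbour, compound 1, with the structure `CC1=C(C(=O)OC(C)C)[C@@H](c2ccco2)NC(=S)N1`, gives in this assay a value of 8%, a gap beyond the usual scatter. Compound 3, with the structure `CC1=C(C(=O)OC(C)(C)C)C(c2ccoc2)NC(=S)N1`, differs from compound 2 by tert-butyl in place of methyl on an oxygen next to a carbonyl group. Among the compounds with values here, no measured pair shows this change, so its effect is unknown from the data at hand. Compound 3 is estimated to come in near 18%, between 0% and 45%. The expected step in this assay is a number 7 percentage points lower from compound 2 to compound 3 (within the scatter), a modest fall that may not exceed the scatter.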

Compound 3, a percentage reported as inhibition, at one concentration (the size of the read-out at that concentration, not a potency): 18%
Compound 3: middle estimate and measured number agree at the digits printed, within the range that was stated.
By their numbers in this assay, from the lowest: compounds 1, 3 and 2 (each within the scatter of the next, the first and the last beyond it).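

In this assay, going by these compounds alone, the only measured exchange at this place, tert-butyl in place of methyl on an oxygen next to a carbonyl group, reads a number 7 percentage points lower from compound 2 to compound 3 (within the scatter). This place therefore accepts tert-butyl without a change beyond the scatter, which compound 1 and compound 2 could not show, since they differ in more than one place. No measurement at hand offers an explanation for this step. From the compounds shown here alone, whether a longer chain or a benzyl group on this oxygen would behave the same remains open, as does the effect of this exchange on the core of compound 1.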